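Substituent swap on the aromatic carbon: clearance notes

This account rests on a few compounds, and the source may have more. Where it says the series, first, only, none or still open, it means among the compounds named here.

In an ADME assay on microsomes from liver (Mus musculus, strain CD1) for metabolic stability, read by HPLC, using NADPH, with a stated time of 30 min (on this read-out lower numbers stand for slow clearance and higher numbers for fast clearance), compound 2 `COc1cccc(NC(=O)c2nnn(Cc3ccc(C4CC4)cc3)c2N)c1` gives 4.9 mL.min-1.g-1, the highest of the two numbers in hand. The nearest is compound 1 `COc1cccc(NC(=O)c2nnn(Cc3ccc(-n4cccn4)cc3)c2N)c1`, which in this assay gives 2.3 mL.min-1.g-1. For the measured compounds named here, the step between them, a 2.1-fold higher number from compound 1 to compound 2 (0.33 log units; beyond the scatter), is the only measured step at this aromatic carbon.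

Compound 3 `COc1cccc(NC(=O)c2nnn(Cc3ccc([S+](C)[O-])cc3)c2N)c1` differs from compound 2 in one place: a group of 3 heavy atoms (1 carbon, 1 oxygen, 1 sulfur; no ring) in place of a group of 3 heavy atoms (3 carbon; one three-membered non-aromatic ring of carbon only), on an aromatic carbon. The entering group has the same count of heavy atoms as the one it replaces but no ring and one hydrogen-bond acceptor.

Going by the values given here, only the single step of a 2.1-fold higher number from compound 1 to compound 2 (0.33 log units; beyond the scatter) bears on the change, and it concerns the same aromatic carbon, para to a large group. It shows that exchanging the ring-bearing 1H-pyrazol-1-yl for cyclopropyl raised the number modestly and beyond the scatter. Among the compounds with values here, removing the cyclopropyl again is therefore expected to move the number downward by a modest step, roughly back toward compound 1, though with one step as the only guide the range is kept wide.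

For compound 3 the estimate in this assay is 2.6 mL.min-1.g-1, in the range 1.2 mL.min-1.g-1 to 5.5 mL.min-1.g-1. The expected step is a 1.9-fold lower number from compound 2 to compound 3 (0.28 log units; within the scatter).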

Compound 3, intrinsic clearance in microsomes in the Mus musculus assay: 0.5 mL.min-1.g-1
Compound 3: the middle estimate sits 5.2-fold (0.72 log units) above what was measured; measured number outside the range, below it.
By their numbers in the Mus musculus assay, from the lowest: compound 3; then compound 1; then compound 2.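

For the compounds shown here, at this aromatic carbon, intrinsic clearance in microsomes in the Mus musculus assay spans more than the one earlier step showed: the ring-free group gives a 9.8-fold lower number from compound 2 to compound 3 (0.99 log units; beyond the scatter) and a 4.6-fold lower number from compound 1 to compound 3 (0.66 log units; beyond the scatter), and since cyclopropyl and the group that replaces it hold the same count of heavy atoms, that count alone does not set the number. The same change can also be followed in a second read-out, where in a physicochemical assay for solubility, read by nephelometry, at pH 7.4 (a lower number here means a less soluble compound, a higher number a more soluble compound), compound 2 gives 79000 nM. In the physicochemical assay compound 3 gives > 250000 nM, which is a limit of the assay and not a number.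

On these data alone, whether other ring-free groups on this aromatic carbon, such as an amine, a carboxylic acid or a methyl sulfone, would keep the clearance number as low as compound 3 does remains open, and three compounds give no way to tell which feature of the entering group goes with the lower number. How far compound 3 actually stands from compound 2 in the physicochemical assay also remains open: the limit of > 250000 nM in the physicochemical assay, at which 1 of the 2 values shown sits.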